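A few compounds are considered here, and "the series" means these few. Any claim that something is new, unique, unknown or untested is made for them only; others in the source may bear on it.

Measured so far:
- compound 1, `O=C(NO)c1ccc(N(Cc2ccc(C3CCOCC3)cc2)C(=O)[C@H]2CCN2S(=O)(=O)c2c(F)c(F)c(F)c(F)c2F)cc1`: > 10000 nM
- compound 2, `CONC(=O)c1ccc(N(Cc2ccc(C3CCCCC3)cn2)C(=O)[C@H]2CCN2S(=O)(=O)c2c(F)c(F)c(F)c(F)c2F)c(F)c1`: "not determined" (no result reported)

Two compounds have been looked at in a functional assay on MCF7 cells (Homo sapiens) for antiproliferative activity, with a stated time of 72 h; on this read-out lower numbers stand for an effect already at smaller amounts and higher numbers for an effect only at larger amounts of compound. For compound 1 the result is a limit of the assay and not a number: in this assay compound 1 gives > 10000 nM. In this assay, going by the values given here, compound 2 gives "not determined" (no result reported), so its standing among the numbers cannot be placed; the only other value shown is the limit of > 10000 nM in this assay, at which 1 of the 2 values shown sits.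

Compound 3, `Cn1ccc2cc(N(Cc3ccc(C4CCCCC4)cn3)C(=O)[C@H]3CCN3S(=O)(=O)c3c(F)c(F)c(F)c(F)c3F)ccc2c1=O`, is still to be measured. It differs from compound 2 in one place: a group of 12 heavy atoms (10 carbon, 1 nitrogen, 1 oxygen; one six-membered aromatic ring of carbon only, one six-membered aromatic ring with 1 hetero atom) in place of a group of 12 heavy atoms (8 carbon, 1 nitrogen, 2 oxygen, 1 fluorine; one six-membered aromatic ring of carbon only), on an amide-type nitrogen. Among the compounds with values here, with no step between measured compounds, there is nothing to set a size or direction for this change, and the one measured value in this assay is a limit. The expectation for compound 3 in this assay therefore leans toward a weak effect, with a wide spread and a real chance that only a limit will be reported. The estimate for compound 3 is 3000 nM, expected to fall between 400 nM and 20000 nM.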

Compound 3, half-maximal effective concentration: 2800 nM
The estimate for compound 3 lay 1.1-fold (0.03 log units) above the measured number, within the range that was stated.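

No step can be read for compound 3, as its one-place neighbour, compound 2, has no reported result, and compound 1 differs in more than one place. Compound 1 gives a limit of the assay and not a number: the limit of > 10000 nM in this assay, at which 1 of the 3 values shown sits.

The compounds shown leave open how replacing the 2-fluoro-4-(methoxycarbamoyl)phenyl group with the group in compound 3 alters the effect on the cells.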